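Linker and ring swap on a dichlorophenyl piperazine amide

The source may hold more compounds than are shown below. What is called first, only, known or untested is meant among the compounds shown, and "the series" means these compounds.

Measured so far:
compound 1 `O=C(COCc1ccncn1)N1CCN(c2ccc(Cl)cc2Cl)CC1` – 2800 nM
compound 2 `O=C(COCc1cncs1)N1CCN(c2ccc(Cl)cc2Cl)CC1` – 1280 nM

Both compounds share the same core; they differ only in the aromatic ring on the saturated chain carbon bound to the ether oxygen. Among the measured compounds shown here, in a functional assay on HEK293 cells for positive allosteric modulation of metabotropic glutamate receptor 5 (Homo sapiens), read by FLIPR and calcium flux (on this read-out lower numbers stand for an effect already at smaller amounts and higher numbers for an effect only at larger amounts of compound), compound 2 gives the lowest of the two numbers, and its only neighbour is compound 1, reached by the step of a 2.2-fold lower number from compound 1 to compound 2 (0.34 log units; beyond the scatter).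

Compound 3 `O=C(CNCc1ccncc1)N1CCN(c2ccc(Cl)cc2Cl)CC1` is not yet measured. It differs from compound 2 by ((pyridin-4-yl)methyl)amino in place of (1,3-thiazol-5-yl)methoxy on a saturated chain carbon bound to a carbonyl carbon. For the measured compounds named here, the one measured step, from compound 1 to compound 2, concerns a change of the aromatic ring while the ether oxygen is kept; it says nothing about replacing that oxygen with an amino group, so it bears on the new step only loosely. A six-membered ring with one nitrogen returns in place of the five-membered ring, and the measured step was in the direction of a lower number for the five-membered ring. Compound 3 is therefore expected to give a somewhat higher number than compound 2, with the step of a 2.7-fold higher number from compound 2 to compound 3 (0.44 log units; beyond the scatter); the estimate for compound 3 in this assay is 3500 nM, within 900 nM to 14000 nM.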

Compound 3, half-maximal effective concentration: 8500 nM
Estimate against measurement, compound 3: 2.4-fold (0.39 log units) below, within the range that was stated.
By their numbers in this assay, from the lowest: compound 2; then compound 1; then compound 3.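

In this assay, the ((pyridin-4-yl)methyl)amino group on a saturated chain carbon bound to a carbonyl carbon gives a 6.6-fold higher number from compound 2 to compound 3 (0.82 log units; beyond the scatter) and also a 3.0-fold higher number from compound 1 to compound 3 (0.48 log units; beyond the scatter), both beyond the scatter. The earlier pair had shown only a change of ring with the ether oxygen kept, whereas these steps show that this place also responds when the whole group is exchanged, and that neither ether-linked group gives a number as high as the amino-linked one does. Nothing at hand explains this rise.

Each of these steps changes the ring and the linking atom together, so the compounds shown leave open how much of the rise belongs to the amino link and how much to the pyridin-4-yl ring; a (pyridin-4-yl)methoxy group or a ((1,3-thiazol-5-yl)methyl)amino group at this place would separate the two. Also open, on these data alone, is how a methyl group on the linking nitrogen, or a longer chain between that nitrogen and the ring, would read in this assay.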